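Compound 4: fluoro for hydrogen, expected effect in the series

The source may report more compounds than this note shows. Statements on the series, on what has been measured and on what is new or still open speak of the compounds shown alone.

Compound 2 `CNC(=O)c1ccc(Sc2ccc(NC(=S)Nc3cccc(C(F)(F)F)c3)cc2)nc1` is the reference point. Among the compounds with values here, in a functional assay on B16-BL6 cells (Mus musculus) for cytotoxicity, read by MTT assay, with a stated time of 48 h (a lower number here means a stronger inhibitor, a higher number a weaker inhibitor), compound 2 gives 53100 nM, the second highest of the three numbers measured so far. Its nearest neighbour is compound 3 `CNC(=O)c1ccc(Sc2ccc(NC(=S)Nc3ccc(Cl)cc3)cc2)nc1`, which in this assay gives 69300 nM; the step between them is a 1.3-fold higher number from compound 2 to compound 3 (0.12 log units; within the scatter). Furthest from it is compound 1 `CNC(=O)c1ccc(Sc2ccc(NC(=S)Nc3cc(C(F)(F)F)cc(C(F)(F)F)c3)cc2)nc1`, which in this assay gives 36100 nM; that step is a 1.5-fold higher number from compound 1 to compound 2 (0.17 log units; within the scatter). Both steps lie within the scatter, so the three measured compounds are not separated by the present data.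

Compound 4 `CNC(=O)c1ccc(Sc2ccc(NC(=S)Nc3ccc(F)c(C(F)(F)F)c3)cc2)nc1` differs from compound 2 in one place: fluoro in place of hydrogen on an aromatic carbon. The change sits on the same six-membered aromatic ring of carbon only that is altered in both measured steps, and those steps are the ones that bear on it. Removing a whole trifluoromethyl group, a 1.5-fold higher number from compound 1 to compound 2 (0.17 log units; within the scatter), and exchanging the entire 3-(trifluoromethyl)phenyl for 4-chlorophenyl, a 1.3-fold higher number from compound 2 to compound 3 (0.12 log units; within the scatter), each stayed within the scatter. A single fluorine entering on that ring is a smaller change than either, so no step beyond the scatter is expected in this assay in either direction. The expected step is a 1.1-fold lower number from compound 2 to compound 4 (0.03 log units; within the scatter). Compound 4 is estimated at 50000 nM, with a range from 25000 nM to 100000 nM.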

Compound 4, half-maximal inhibitory concentration: 29300 nM
For compound 4 the middle estimate is 1.7-fold (0.23 log units) above the measured one, within the range that was stated.
By their numbers in this assay, from the lowest: compounds 4, 1, 2 and 3 (each within the scatter of the next, the first and the last beyond it).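

Working notes on this position: in this assay the carbon ortho to a trifluoromethyl group and para to a large group takes fluoro in place of hydrogen with a step that stays within the scatter (a 1.8-fold lower number from compound 2 to compound 4 (0.26 log units; within the scatter)). Compound 4 is the only compound shown that carries a halogen and a trifluoromethyl group on this ring, so this pairing is now seen to give no separation from compound 2 in this assay. Nothing available bears on the reason for this step.

The compounds shown leave open whether a methoxy group, an amine or a carboxylic acid on the same carbon would give a step beyond the scatter, or whether this position stays as undiscriminating with those groups as it does with fluoro. They also leave open whether chloro on that carbon with the trifluoromethyl group kept, or fluoro there with the trifluoromethyl group replaced by hydrogen, would read as compound 4 does.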